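The compounds below may be only part of what the source reports. "The series", "measured", "known", "first", "only" and "open" are said of these compounds alone.

Measured compounds:
Compound 1, `COc1cccc(N2CCN(C(=O)C3CN(S(=O)(=O)c4ccc(OC)c5ccccc45)c4ccccc43)CC2)c1`, gives 63.1 nM in a functional assay on CHO cells for antagonist activity at 5-hydroxytryptamine receptor 6 (Homo sapiens), read by FLIPR; a higher number here means a weaker inhibitor, a lower number a stronger inhibitor.
Compound 2, `CN1CCC(N(C)C(=O)C2CN(S(=O)(=O)c3ccc4c(c3)OCCO4)c3ccccc32)CC1`, gives 50.1 nM in this assay.

Among the measured compounds shown here, of the two numbers measured so far, compound 2 shows the lower one, yet the gap between compound 2 and compound 1 lies within the usual scatter of repeated measurements, so the two compounds cannot be told apart on these data. For the measured compounds named here, no pair of measured compounds differs in just one place, so no single structural change has yet been tied to a shift in the numbers.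

Compound 3, `CN1CCC(N(C)C(=O)C2CN(S(=O)(=O)c3ccc(C(F)(F)F)cc3)c3ccccc32)CC1`, has not been measured. It differs from compound 2 in one place: 4-(trifluoromethyl)phenyl in place of 2,3-dihydro-1,4-benzodioxin-6-yl on a sulfonyl sulfur. Sulfonyl-linked aromatic groups of this kind are present in both measured compounds, and in both they are paired with numbers of the same order. Going by the values given here, with no measured step to lean on, the expectation for compound 3 is a number near that of compound 2, with the step of a 1.2-fold higher number from compound 2 to compound 3 (0.08 log units; within the scatter) expected to fall within the scatter, in either direction. Compound 3 is therefore estimated at 60 nM, with a range from 20 nM to 200 nM.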

Compound 3, inhibition constant: 25.1 nM
The estimate for compound 3 lay 2.4-fold (0.38 log units) above the measured number; low and high end bracket the measured number.
By their numbers in this assay, from the lowest: compounds 3, 2 and 1 (each within the scatter of the next, the first and the last beyond it).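

Among the compounds shown here, on the sulfonyl sulfur, 4-(trifluoromethyl)phenyl in place of 2,3-dihydro-1,4-benzodioxin-6-yl gives a 2.0-fold lower number from compound 2 to compound 3 (0.30 log units; within the scatter) in this assay and is the first single change that can be read here, though the two numbers cannot be firmly separated. The two groups differ markedly despite having 10 heavy atoms each: the entering group has fluorine instead of oxygen, lacks the non-aromatic ring and has 0 hydrogen-bond acceptors against 2, so this pair shows that the two oxygens of the leaving group are not needed for a number of this order. Nothing given here explains why two such different groups give such close numbers.

The compounds shown compare only these two groups with the rest of the structure held fixed, so it remains open how an unsubstituted phenyl, or a phenyl carrying a carboxylic acid or an amine, would read at this place. Compound 1 differs from compound 2 and compound 3 in more than one place, so the contributions of its separate groups remain unresolved.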